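The source may report more compounds than this note shows. Statements on the series, on what has been measured and on what is new or still open speak of the compounds shown alone.

Measured in a functional assay on MGC-803 cells (Homo sapiens) for cytotoxicity, read by MTT assay, with a stated time of 48 h; a lower number here means a stronger inhibitor, a higher number a weaker inhibitor:

- compound 1 `CC1=NN(C(=O)CSc2ccccc2)[C@@H](c2cc(Br)cc(Br)c2O)C1`: 12700 nM
- compound 2 `O=C(CSc1ccc(Br)cc1)N1N=C(c2cc3ccccc3oc2=O)C[C@@H]1c1ccccc1C(F)(F)F`: 21300 nM
- compound 3 `O=C(CSc1ccc(Br)cc1)N1N=C(c2cc3ccccc3oc2=O)C[C@@H]1c1ccc(C(F)(F)F)cc1`: 10800 nM

Compound 1 lies within the usual scatter of both compound 2 and compound 3, so these numbers cannot be told apart. Compound 4 `CC1=NN(C(=O)CSc2nc3ccccc3s2)[C@@H](c2cc(Br)cc(Br)c2O)C1` keeps the core of compound 1 and changes one group: 1,3-benzothiazol-2-yl in place of phenyl on a sulfur. Here 1,3-benzothiazol-2-yl takes the place of phenyl on a sulfur whose other neighbour is a saturated chain carbon.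

Among the measured compounds shown here, only one measured step is available, a 2.0-fold lower number from compound 2 to compound 3 (0.29 log units; within the scatter). It concerns a group on a saturated ring carbon, not the group on the sulfur, so it bears on this change only indirectly. For the measured compounds named here, it does show a small step, but no measured pair isolates a swap on the sulfur, and the data therefore give no direction for this one. Compounds 2 and 3 also differ from compound 1 in several places, yet their values stay within the scatter of its value. In this assay, no step beyond the scatter is therefore expected. The expected step is a 1.3-fold lower number from compound 1 to compound 4 (0.10 log units; within the scatter), and this small size is an estimate, not a measured trend. For compound 4 the estimated value is 10000 nM, with an expected range of 3000 nM to 30000 nM.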

Compound 4, half-maximal inhibitory concentration: 7800 nM
Compound 4: middle estimate off by 1.3-fold (0.11 log units), on the high side, and the stated range covers the measured number.
By their numbers in this assay, from the lowest: compounds 4, 3, 1 and 2 (each within the scatter of the next, the first and the last beyond it).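

Among the compounds shown here, the swap of phenyl for 1,3-benzothiazol-2-yl on a sulfur whose other neighbour is a saturated chain carbon is the first measured change at this place, and in this assay it gives a 1.6-fold lower number from compound 1 to compound 4 (0.21 log units; within the scatter). The entering group brings a second aromatic ring and hydrogen-bond acceptors that phenyl does not have, yet the step stays within the scatter, so this single pair shows that the position accepts the larger group but gives no reliable gain or loss in either direction. Nothing measured on either group is available to explain the size of this step.

For the compounds shown here, with only one swap on the sulfur, it remains open whether a quite different group there, such as a carboxylic acid, an amine or a longer chain, would give a step beyond the scatter. Also open, as far as these compounds go, is whether 1,3-benzothiazol-2-yl in place of phenyl would give a step of similar size if the group on the saturated ring carbon were different.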